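Sulfonamide aryl swap: isoxazole to chloropyridine in compound 1

The source may hold more compounds than are shown below. What is called first, only, known or untested is meant among the compounds shown, and "the series" means these compounds.

Measured so far:
compound 1 `Cc1noc(C)c1S(=O)(=O)N1CCC(N2CCC(C)CC2)CC1`: > 5000 nM
compound 2 `CCc1cc(Br)ccc1S(=O)(=O)N1CCC(N2CCC(C)CC2)CC1`: 0.6 nM
compound 3 `CC1CCCN(C2CCN(S(=O)(=O)c3ccc(OC(F)F)cc3)CC2)C1`: 105 nM

All three share a sulfonyl-linked bipiperidine core and differ in the aryl group on the sulfonyl sulfur and in where the methyl sits on the outer piperidine. Among the measured compounds shown here, in a functional assay on DLD-1 cells (Homo sapiens) for antiproliferative activity, read by CellTiter-Glo, with a stated time of 72 h (a lower number here means a stronger inhibitor, a higher number a weaker inhibitor), compound 1 gives only a limit, > 5000 nM, so no number is known for it; it is the one compound that sits at the limit of > 5000 nM in this assay, at which 1 of the 3 values shown sits. Compound 2 gives 0.6 nM and compound 3 gives 105 nM, both with a six-membered aromatic ring on the sulfonyl sulfur.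

Compound 4 `CC1CCN(C2CCN(S(=O)(=O)c3ccc(Cl)nc3)CC2)CC1` is not yet measured. It differs from compound 1 by 6-chloropyridin-3-yl in place of 3,5-dimethyl-1,2-oxazol-4-yl on a sulfonyl sulfur. For the measured compounds named here, this replaces the one aryl group among the three that gives only a limit with a six-membered aromatic ring of the kind carried by compound 2 and compound 3. The step is therefore expected to be large and towards a stronger inhibitor, well beyond the scatter, estimated as an at least 83-fold lower number from compound 1 to compound 4 (1.92 log units; beyond the scatter). For compound 4 the expected value is 60 nM, with a range from 8 nM to 600 nM.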

Compound 4, half-maximal inhibitory concentration: 3700 nM
For compound 4 the middle estimate is 62-fold (1.79 log units) below the measured one, and the stated range ends below it.
By their numbers in this assay, from the lowest: compound 2; then compound 3; then compound 4. At a limit, above all of these: compound 1.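

In this assay the step reads an at least 1.3-fold lower number from compound 1 to compound 4 (0.13 log units; that floor lies within the scatter), so 6-chloropyridin-3-yl on a sulfonyl sulfur gives no gain over 3,5-dimethyl-1,2-oxazol-4-yl that can be told from the scatter. The true size of this step cannot be read because compound 1 gives only a limit: the limit of > 5000 nM in this assay, at which 1 of the 4 values shown sits. A six-membered aromatic ring at this position is therefore not enough in itself: on the same core, compound 4 gives 3700 nM and compound 2 gives 0.6 nM, so the identity of the aryl group matters greatly here.

Open, from the compounds shown here alone, is whether a methoxy group or an amine in place of the chlorine of compound 4 would change its value. Also open, going by these compounds, is whether the gap to compound 2 follows the pyridine ring nitrogen, the chlorine, or the ethyl and bromine of compound 2.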